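The source may hold more compounds than are shown below. What is called first, only, known or untested is meant among the compounds shown, and "the series" means these compounds.

Measured compounds in an assay for binding affinity to adenosine receptor A1 (Bos taurus); on this read-out lower numbers stand for stronger inhibition and higher numbers for weaker inhibition:
compound 1 `Cc1ccc2c(N=[N+]=[N-])c(Cc3ccccc3)cnc2n1` gives 3340 nM.
compound 2 `Cc1ccc2c(O)c(C(=O)NN3CCOCC3)cnc2n1` gives > 10000 nM, a limit of the assay and not a number.
compound 3 `Cc1ccc2c(O)c(C(=O)NCc3ccc([N+](=O)[O-])cc3)cnc2n1` gives 1630 nM.

Compound 3 holds the lowest of the two numbers; compound 1 stands above it by a gap beyond the usual scatter. Compound 2 sits at the limit of > 10000 nM in this assay, at which 1 of the 3 values shown sits.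

Compound 4 `Cc1ccc2c(O)c(C(=O)NCc3ccc(NC(=O)c4ccccc4)cc3)cnc2n1` differs from compound 3 in one place: benzamido in place of nitro on an aromatic carbon. Among the compounds with values here, no step between measured compounds covers this change. The expected step from compound 3 to compound 4 is a 1.1-fold lower number from compound 3 to compound 4 (0.04 log units; within the scatter), not beyond the scatter in either direction. Compound 4 is therefore estimated at 1500 nM, with a range from 400 nM to 6000 nM.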

Compound 4, inhibition constant: 7590 nM
Compound 4: middle estimate off by 5.1-fold (0.70 log units), on the low side; the measured number lies above the stated range.
By their numbers in this assay, from the lowest: compound 3; then compound 1; then compound 4. At a limit, above all of these: compound 2.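

In this assay benzamido in place of nitro on an aromatic carbon gives a 4.7-fold higher number from compound 3 to compound 4 (0.67 log units; beyond the scatter) and so shows that this position is sensitive to its substituent. The entering group brings a six-membered aromatic ring and a hydrogen-bond donor, but this single pair cannot separate the two. No measurement at hand gives a cause for this step.

Open, from the compounds shown here alone, is whether a primary amine or an acetamido group at this place would stay near compound 3 or move towards compound 4.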